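Iodo on the Core: Expected Tolerance of Compound 4

The source may hold more compounds than are shown below. What is called first, only, known or untested is meant among the compounds shown, and "the series" means these compounds.

Measured so far in an ADME assay on RAW264.7 cells (Mus musculus) for cytotoxicity, read by MTT assay, with a stated time of 24 h; a higher number here means that more compound is tolerated, a lower number that less compound is tolerated:
Compound 1, `O=c1oc2ccccc2c(=O)n1-c1ccc(Cl)cc1F`: 24400 nM
Compound 2, `O=C(Nc1ccc(I)cc1F)c1cc(F)ccc1O`: 7400 nM
Compound 3, `O=c1oc2ccc(F)cc2c(=O)n1-c1ccc(F)cc1F`: 19900 nM

Compound 1 and compound 3 lie within the usual scatter of each other in this assay, so no order between them can be claimed. Compound 2 gives a clearly lower number than compound 1, beyond the scatter, meaning less of it is tolerated.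

Compound 4, `O=c1oc2ccc(I)cc2c(=O)n1-c1ccc(Cl)cc1F`, differs from compound 1 by iodo in place of hydrogen on an aromatic carbon. Going by the values given here, no measured pair shows the effect of such a change, so the expectation rests on compound 1 alone. A modest downward step is expected, possibly within the scatter: the step from compound 1 to compound 4 is estimated at a 1.6-fold lower number from compound 1 to compound 4 (0.21 log units; within the scatter). Compound 4 is therefore expected to give about 15000 nM, within a range of 6000 nM to 35000 nM.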

Compound 4, half-maximal cytotoxic concentration: 8900 nM
For compound 4 the middle estimate is 1.7-fold (0.23 log units) above the measured one; low and high end bracket the measured number.
By their numbers in this assay, from the lowest: compounds 2 and 4 (each within the scatter of the next); then compounds 3 and 1 (each within the scatter of the next).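

Iodo in place of hydrogen on this aromatic carbon of the shared core gives a 2.7-fold lower number from compound 1 to compound 4 (0.44 log units; beyond the scatter) in this assay and is the one single change shown here. So this position is sensitive to the change: with one iodine atom added and the rest of compound 1 kept, less compound is tolerated. Nothing available here explains this step.

Going by these compounds, it remains open whether an amine or a carboxylic acid on the same carbon would lower the number as well. A single step also cannot show whether iodo would act the same way elsewhere on the core.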